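Chlorophenyl for Methylphenyl on a Sulfonamide Hydrazide Pair

This account rests on a few compounds, and the source may have more. Where it says the series, first, only, none or still open, it means among the compounds named here.

compound 1 (`Cc1ccc(C(=O)NNC(=O)c2cccc(NS(=O)(=O)c3cnc(O)nc3O)c2)cc1`), a limit in a functional assay on OVCAR-3 cells (Homo sapiens) for antiproliferative activity, read by MTT assay, with a stated time of 24 h; a lower number here means a stronger inhibitor, a higher number a weaker inhibitor: > 20000 nM
compound 2 (`O=C(NNC(=O)c1ccccc1Cl)c1cccc(NS(=O)(=O)c2cnc(O)nc2O)c1`): 7300 nM
compound 3 (`Cc1ccc(C(=O)NNC(=O)c2ccccc2NS(=O)(=O)c2cnc(O)nc2O)cc1`): 12900 nM

In this assay compound 1 reaches only the limit (the limit of > 20000 nM in this assay, at which 1 of the 3 values shown sits). The step of an at least 2.7-fold lower number from compound 1 to compound 2 (0.43 log units; beyond the scatter) is therefore a lower bound on the change (2-chlorophenyl in place of 4-methylphenyl on a carbonyl carbon). Compound 2 and compound 3 sit within the scatter of each other. How the core of compound 3 differs from that of compound 1 is not broken down here. Compound 4 (`O=C(NNC(=O)c1ccccc1NS(=O)(=O)c1cnc(O)nc1O)c1ccccc1Cl`) is not yet measured; it differs from compound 3 by 2-chlorophenyl in place of 4-methylphenyl on a carbonyl carbon, the same change in the same place. From compound 3 to compound 4 the step is expected to be about a 2.9-fold lower number from compound 3 to compound 4 (0.46 log units; beyond the scatter), resting on the step of an at least 2.7-fold lower number from compound 1 to compound 2 (0.43 log units; beyond the scatter) seen on the other core. Compound 4 is estimated at 4500 nM, between 1500 nM and 13000 nM.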

Compound 4, half-maximal inhibitory concentration: 18200 nM
The estimate for compound 4 lay 4.0-fold (0.61 log units) below the measured number, and the stated range ends below it.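

In this assay, the change from 4-methylphenyl to 2-chlorophenyl on a carbonyl carbon gives a 1.4-fold higher number from compound 3 to compound 4 (0.15 log units; within the scatter), so the gain seen on the core of compound 1 does not carry over to the core of compound 3: the same change on two cores in this assay, an at least 2.7-fold lower number (0.43 log units; beyond the scatter) from compound 1 to compound 2 and a 1.4-fold higher number (0.15 log units; within the scatter) from compound 3 to compound 4, at least 3.8-fold (0.58 log units) apart, beyond the scatter of two such steps. From the compounds shown here alone, the earlier step rests on a limit, so its true size stays unknown: the limit of > 20000 nM in this assay, at which 1 of the 4 values shown sits. With one pair on each core, the data show neither why the two cores part nor how the change would behave on any further core.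

Going by these compounds, it remains open how a morpholine or a pyridine ring on the same carbonyl carbon would fare on either core. A single further pair of this kind could show whether the cores diverge more generally.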